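Removing the Nitro Group from an Anticonvulsant Imine

The source may hold more compounds than are shown below. What is called first, only, known or untested is meant among the compounds shown, and "the series" means these compounds.

Three imines that share one core have been tested in a functional assay on the whole organism (strain Swiss albino) with Mus musculus as the target, in the maximal electroshock model; on this read-out lower numbers stand for an effect already at smaller amounts and higher numbers for an effect only at larger amounts of compound. Compound 1 `O=[N+]([O-])c1ccc(/C=N/Cc2cccnc2)cc1` gives 61.4 mg/kg in this assay, which is the highest of the three numbers. Compound 2 `C/C(=N\Cc1cccnc1)c1ccccc1` gives 55.7 mg/kg in this assay, and compound 3 `C(=C/c1ccccc1)\C=N\Cc1cccnc1` gives 36.3 mg/kg in this assay. The gaps between compound 1 and each of the other two lie within the usual scatter of repeated measurements, so on these numbers the three compounds cannot be told apart.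

Compound 4 `C(=N/Cc1cccnc1)\c1ccccc1` has not yet been measured. It differs from compound 1 in one place: hydrogen in place of nitro on an aromatic carbon. For the measured compounds named here, no measured pair shows what this change does, so its size has to be judged from the three values alone. Because compound 1 gives 61.4 mg/kg and its neighbours sit close to that, the change is expected to stay within the scatter, a 1.2-fold lower number from compound 1 to compound 4 (0.09 log units; within the scatter), with no clear direction. Compound 4 is estimated to give about 50 mg/kg in this assay, somewhere between 25 mg/kg and 100 mg/kg.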

Compound 4, dose for half-maximal effect: 53 mg/kg
Beside the measured number, compound 4's estimate is 1.1-fold (0.03 log units) below it; the measured number falls inside the stated range.
By their numbers in this assay, from the lowest: compounds 3, 4, 2 and 1 (each within the scatter of the next).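

Replacing the nitro group with hydrogen on the aromatic carbon gives a 1.2-fold lower number from compound 1 to compound 4 (0.06 log units; within the scatter) in this assay. This is the first pair shown that differs in this one place only, and it shows that the number does not depend on the nitro group at this position: with only hydrogen there, compound 4 cannot be told apart from compound 1. No measurement shown here bears on why removing the nitro group leaves the number within the scatter.

With only nitro and hydrogen shown at this position, it remains open whether an amine, a methoxy group or a chlorine atom there would also stay within the scatter or would move the number beyond it. Also open, as far as these compounds go, is whether the same change would have as small an effect on the cores of compound 2 and compound 3.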